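This account rests on a few compounds, and the source may have more. Where it says the series, first, only, none or still open, it means among the compounds named here.

Measured in a toxicity assay on THP-1 cells (Homo sapiens) for inhibition; a lower number here means that less compound is tolerated, a higher number that more compound is tolerated:
- compound 1 `Cn1c(-c2ccc(Br)cc2)cnc1NC(=O)c1ccc(F)cc1`: 46000 nM
- compound 2 `COc1ccc(-c2cnc(NC(=O)c3ccno3)n2C)cc1`: > 100000 nM (a limit, not a number)
- compound 3 `COc1ccc(-c2cnc(NC(=O)c3ccc(O)cc3)n2C)cc1`: > 100000 nM (a limit, not a number)

Among the measured compounds shown here, compound 1, at 46000 nM, holds the only true number in this small set, so it cannot be ranked against a spread of other readings. Compound 2 and compound 3 both stand at the limit of > 100000 nM in this assay, at which 2 of the 3 values shown sit.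

Compound 4 `Cc1ccccc1-c1cnc(NC(=O)c2ccc(F)cc2)n1C` is compound 1 with 2-methylphenyl in place of 4-bromophenyl on an aromatic carbon. The core and the amide side are unchanged.

For the measured compounds named here, the only measured step is a step that the two limits leave unreadable from compound 2 to compound 3. It concerns the group on a carbonyl carbon, not the aromatic carbon changed here, and it has no readable size to carry over. Going by the values given here, no measured step therefore speaks directly to this swap, and no change beyond the usual scatter is expected in this assay. A slight lean towards more tolerance rests only on compound 2 and compound 3, which reach (the limit of > 100000 nM in this assay, at which 2 of the 3 values shown sit). The expected change is a 1.2-fold higher number from compound 1 to compound 4 (0.08 log units; within the scatter).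

For compound 4 the estimated value is 55000 nM, with an expected range of 25000 nM to 100000 nM.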

Compound 4, half-maximal cytotoxic concentration: > 50000 nM
Compound 4 ended at the assay's limit; the forecaster's own chance of this, stated with the estimate: 30%; the middle value is on the limit's open side.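

Swapping 4-bromophenyl for 2-methylphenyl gives the first readable step at this aromatic carbon in this assay, and it is only a floor: an at least 1.0-fold higher number from compound 1 to compound 4 (0.03 log units; that floor lies within the scatter). For compound 4, the reading of > 50000 nM is a limit of the assay, not a number. The swap removes the bromine and adds a methyl group without any sign that less compound is tolerated, but how far the true value lies from this reading cannot be told, and the result rests on this ceiling: the limit of > 50000 nM in this assay, at which 1 of the 4 values shown sits.

The swap changes both the substituent and where it sits on the phenyl ring, and the compounds shown do not separate these two changes. From the compounds shown here alone, it also stays open how a 4-methylphenyl group, or a phenyl ring carrying an amine or a carboxylic acid, would read at this carbon.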